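This account rests on a few compounds, and the source may have more. Where it says the series, first, only, none or still open, it means among the compounds named here.

Compound 1 `CCOC(=O)c1ccc2nc(NC(=O)CNC(=O)c3nn(-c4ccccc4)c(=O)c4ccccc34)sc2c1` is the amide-linked member of the series built on a fused two-ring core. In an assay on L cells for inhibition of Protein-serine O-palmitoleoyltransferase porcupine (Mus musculus), read by reporter gene assay, with a stated time of 24 h (on this read-out lower numbers stand for an effect already at smaller amounts and higher numbers for an effect only at larger amounts of compound), compound 1 gives only a limit, > 25000 nM, and no number. For the measured compounds named here, it is the one value among the three that sits at the limit of > 25000 nM in this assay, at which 1 of the 3 values shown sits. The two compounds on the other core read differently. In this assay compound 2 `O=C(CSc1nc2c(c(=O)n1-c1ccccc1)SCC2)Nc1ccc(-c2ccccc2)nc1` gives 0.3 nM. In this assay compound 3 `O=C(CSc1nc2c(c(=O)n1-c1ccccc1)SCC2)Nc1ccc(N2CCCCC2)cc1` gives 30 nM. Nothing connects compounds 2 and 3 to compound 1 by a single change, so their numbers say nothing about the core of compound 1 beyond the bare contrast.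

Compound 4 `O=C(CNC(=O)c1nn(-c2ccccc2)c(=O)c2ccccc12)Nc1nc2ccccc2s1` is to be measured in this assay. It differs from compound 1 in one place: hydrogen in place of ethoxycarbonyl on an aromatic carbon. Going by the values given here, no measured pair on this core tells what such a removal does. Compound 1 stands at the limit, so the step from compound 1 to compound 4 is expected to be a number no higher from compound 1 to compound 4 (the limit leaves the size open), with no movement beyond the scatter the likelier outcome. The estimate for compound 4 in this assay is 25000 nM, with a range from 3000 nM to 100000 nM, and a fair chance that the readout is again only a limit.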

Compound 4, half-maximal effective concentration: 2600 nM
Beside the measured number, compound 4's estimate is 9.6-fold (0.98 log units) above it; the whole stated range lies above it.
By their numbers in this assay, from the lowest: compound 2; then compound 3; then compound 4. At a limit, above all of these: compound 1.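

In this assay, for the compounds shown here, hydrogen in place of ethoxycarbonyl on the aromatic carbon gives an at least 9.6-fold lower number from compound 1 to compound 4 (0.98 log units; beyond the scatter), and this single step is the first on this core. Going by these compounds alone, the earlier compounds offered only a bare contrast between two cores, whereas this step shows that the ethoxycarbonyl at this place, meta to a fused ring and para to a fused ring, is not required for a measurable effect: compound 4 gives 2600 nM, a real number where the core had so far offered none. Compound 1 reads only as a limit, so the step has a lower bound and its full size stays open: the limit of > 25000 nM in this assay, at which 1 of the 4 values shown sits.

From the compounds shown here alone, it remains open whether the ester itself is what holds the reading back or whether any group on this carbon would do the same, and a carboxylic acid, a primary amide or a methyl at this place would separate those two readings. One step on one position also says nothing about how the rest of the core of compound 4 responds to change.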